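Swapping Furan for Thiophene on the Ketone Carbonyl

A few compounds are considered here, and "the series" means these few. Any claim that something is new, unique, unknown or untested is made for them only; others in the source may bear on it.

Compound 1 `COc1ccc(-c2cc3ccccc3nc2/C=C/C(=O)c2ccc(N)cc2)cc1` and compound 2 `COc1ccc(-c2cc3ccccc3nc2/C=C/C(=O)c2ccco2)cc1` share one core and differ only in the aromatic group on the carbonyl carbon. In a functional assay on MCF7 cells (Homo sapiens) for antiproliferative activity, read by XTT assay, with a stated time of 72 h (a lower number here means a stronger inhibitor, a higher number a weaker inhibitor), compound 1 gives 6920 nM, while compound 2 gives 710 nM. Among the measured compounds shown here, the step of a 9.7-fold lower number from compound 1 to compound 2 (0.99 log units; beyond the scatter) is the only measured step, and it leaves compound 2 at the lower of the two numbers, with compound 1 as its nearest neighbour at a higher value beyond the scatter. Compound 3 `COc1ccc(-c2cc3ccccc3nc2/C=C/C(=O)c2cccs2)cc1` is not yet measured; it differs from compound 2 by thiophen-2-yl in place of furan-2-yl on a carbonyl carbon. The measured step from compound 1 to compound 2 concerns the same place on the carbonyl carbon, but it exchanges 4-aminophenyl for furan-2-yl, a different substitution from the one now in question, so it bears on it only indirectly. For the measured compounds named here, no measured pair exchanges furan-2-yl for thiophen-2-yl directly. For compound 3 a step of a 1.0-fold lower number from compound 2 to compound 3 (0.01 log units; within the scatter) is therefore expected, which stays within the scatter. The estimate for compound 3 in this assay is 700 nM, with a range from 300 nM to 1700 nM.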

Compound 3, half-maximal inhibitory concentration: 1030 nM
Compound 3: middle estimate off by 1.5-fold (0.17 log units), on the low side; the measured number falls inside the stated range.
By their numbers in this assay, from the lowest: compounds 2 and 3 (each within the scatter of the next); then compound 1.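

The exchange of furan-2-yl for thiophen-2-yl on the carbonyl carbon, which puts sulfur where oxygen stood in the five-membered aromatic ring, gives a 1.5-fold higher number from compound 2 to compound 3 (0.16 log units; within the scatter) in this assay, so the two groups cannot be told apart in this assay. The measured step from 4-aminophenyl to thiophen-2-yl, a 6.7-fold lower number from compound 1 to compound 3 (0.83 log units; beyond the scatter), lies beyond the scatter and runs in the same direction as a 9.7-fold lower number from compound 1 to compound 2 (0.99 log units; beyond the scatter), which shows that the lower number seen earlier is not confined to furan-2-yl but is shared by both five-membered aromatic groups, and none of the three compounds goes against this. Nothing available explains why the numbers at this position fall as they do.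

The compounds shown leave open whether the higher number of compound 1 goes with the amine of 4-aminophenyl or with the phenyl ring that carries it, a question that an unsubstituted phenyl on the same carbonyl carbon could separate. They also leave open whether a nitrogen-containing group such as pyrrol-2-yl or pyridin-3-yl would stay with the furan-2-yl and thiophen-2-yl compounds or with compound 1.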